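A few compounds are considered here, and "the series" means these few. Any claim that something is new, unique, unknown or untested is made for them only; others in the source may bear on it.

Measured in an ADME assay on Vero cells (Chlorocebus sabaeus) for cytotoxicity, with a stated time of 7 days; on this read-out lower numbers stand for higher toxicity in this test and higher numbers for lower toxicity in this test:

Compound 1 `COc1ccc2[nH]c(C(=O)N3CC(=O)N(Cc4ccccc4)[C@@H](CN4CCC5(CC4)CC5)C3)cc2c1`: 17100 nM
Compound 2 `Cc1ccc2[nH]c(C(=O)N3CC(=O)N(Cc4ccccc4)[C@@H](CN4CCC5(CCC5)CC4)C3)cc2c1`: 7800 nM
Compound 3 `COc1ccc2[nH]c(C(=O)N3CC(=O)N(Cc4cccc(OC)n4)[C@@H](Cc4ccccc4)C3)cc2c1`: > 30000 nM

The entry for compound 3, > 30000 nM, is a limit of the assay and not a number. That leaves two true numbers to compare. Compound 1 holds the higher of them, 17100 nM. Compound 2 reads lower, 7800 nM, and this gap lies beyond the usual scatter of repeated measurements.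

The next compound to consider is compound 4 `COc1ccc2[nH]c(C(=O)N3CC(=O)N(Cc4ccccc4)[C@@H](N4[C@H](C)CCC[C@@H]4C)C3)cc2c1`, which differs from compound 1 in one place. On a saturated ring carbon, it carries 2,6-dimethylpiperidin-1-yl in place of a group of 9 heavy atoms: a group of 8 heavy atoms (7 carbon, 1 nitrogen; one six-membered non-aromatic ring with 1 hetero atom) in place of a group of 9 heavy atoms (8 carbon, 1 nitrogen; one three-membered non-aromatic ring of carbon only, one six-membered non-aromatic ring with 1 hetero atom), on a saturated ring carbon.

Within the data shown here, no measured pair of compounds differs in just one place, so no direct precedent exists for this change. The expectation rests on the two true numbers alone, compound 1 with 17100 nM and compound 2 with 7800 nM, since both carry a six-membered non-aromatic ring with 1 hetero atom, as compound 4 does. In this assay, no change beyond the scatter is expected, and the estimated step of a 1.1-fold lower number from compound 1 to compound 4 (0.06 log units; within the scatter) has no firm direction. In this assay, the estimate for compound 4 is 15000 nM, with an expected range from 6500 nM to 30000 nM.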

Compound 4, half-maximal cytotoxic concentration: 1400 nM
For compound 4 the middle estimate is 11-fold (1.03 log units) above the measured one; the whole stated range lies above it.
By their numbers in this assay, from the lowest: compound 4; then compound 2; then compound 1. At a limit, above all of these: compound 3.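

In this assay, replacing the group of compound 1 with 2,6-dimethylpiperidin-1-yl on this saturated ring carbon gives a 12-fold lower number from compound 1 to compound 4 (1.09 log units; beyond the scatter) and so marks higher toxicity in this test. Among these compounds, the earlier compounds offered no pair differing in one place, and this step is the first direct sign that a change here alone can move the read-out well beyond the scatter. The two groups match in hydrogen-bond donors, hydrogen-bond acceptors and net charge, yet they differ in other ways: the leaving group holds a three-membered ring of carbon only, while the entering group lacks that ring and has two defined stereocentres.

Nothing measured in these compounds says which of these differences accounts for the step, or why the number fell. From the compounds shown here alone, whether a plain piperidin-1-yl group or a morpholin-4-yl group on this same carbon would read like compound 1 or like compound 4 remains open.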